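Swapping the Aryl Group on the Carbonyl of Compound 1

The compounds below may be only part of what the source reports. "The series", "measured", "known", "first", "only" and "open" are said of these compounds alone.

Compound 1 `COc1cc(-c2cc(/C=C/C(=O)c3ccc(N)cc3)[nH]n2)cc(OC)c1OC` gives in this test only a limit, > 100000 nM.
Compound 2 `COc1ccc(-c2cc(/C=C/C(=O)c3cc(OC)c(OC)c(OC)c3)[nH]n2)cc1OC` likewise gives only a limit, > 100000 nM.
Compound 3 `COc1ccc(-c2cc(/C=C/C(=O)c3ccc(N)cc3)[nH]n2)cc1` also gives only a limit, > 100000 nM.

In a functional assay on Hs-578T cells (Homo sapiens) for inhibition, read by sulforhodamine B assay, with a stated time of 48 h (on this read-out lower numbers stand for higher toxicity in this test and higher numbers for lower toxicity in this test), compound 1 stands at the limit of the test, > 100000 nM, and it does not stand alone there: the limit of > 100000 nM in this assay, at which 3 of the 3 values shown sit. Among the measured compounds shown here, since every measured compound returns a limit rather than a number, no step between measured compounds can be given, and compound 1 can be ranked neither above nor below compound 2 or compound 3.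

The unmeasured compound 4 `COc1ccc(C(=O)/C=C/c2cc(-c3cc(OC)c(OC)c(OC)c3)n[nH]2)cc1OC` differs from compound 1 in one place: 3,4-dimethoxyphenyl in place of 4-aminophenyl on a carbonyl carbon. Compound 2, which also carries methoxy-bearing aryl groups at both ends of its core, returns a limit in this assay, as does compound 3, whose 4-aminophenyl is kept.

On these grounds compound 4 is expected to return a limit as well; the step from compound 1 to compound 4 is expected to be a number no higher from compound 1 to compound 4 (the limit leaves the size open), none beyond the scatter. The estimate for compound 4 is therefore 100000 nM, with a range from 30000 nM to 300000 nM.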

Compound 4, concentration lethal to 50% of the cells: > 100000 nM
Compound 4: no number, only a limit; the forecaster's own chance of this, stated with the estimate: 75%; the middle value lies on the limit itself.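

The step between compound 1 and compound 4 cannot be read, as both compounds return only a limit in this assay: the limit of > 100000 nM in this assay, at which 4 of the 4 values shown sit.

The compounds shown leave open whether 3,4-dimethoxyphenyl or 4-aminophenyl on the carbonyl carbon gives the lower value in this assay, and whether any compound of this series gives a number there at all.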